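Hydroxyphenyl for methoxyphenyl on a biaryl acid

This account rests on a few compounds, and the source may have more. Where it says the series, first, only, none or still open, it means among the compounds named here.

compound 1, `CCCCCCCCS(=O)(=O)Nc1cc(-c2ccc(Cl)cc2)ccc1C(=O)O`: 18100 nM
compound 2, `CCCCCCCCS(=O)(=O)Nc1cc(-c2ccc(OC)cc2)ccc1C(=O)O`: 13300 nM

In an assay on mitochondria (strain BALB/c) for inhibition of glycerol-3-phosphate acyltransferase 1, mitochondrial (Mus musculus), read by scintillation counting, with a stated time of 10 min (a higher number here means a weaker inhibitor, a lower number a stronger inhibitor), compound 1 gives 18100 nM and compound 2 gives 13300 nM. Compound 2 sits beside compound 1 rather than apart from it, since a 1.4-fold lower number from compound 1 to compound 2 (0.13 log units; within the scatter) falls within the scatter. Compound 3 `CCCCCCCCS(=O)(=O)Nc1cc(-c2ccccc2O)ccc1C(=O)O` differs from compound 2 in that (2-hydroxyphenyl in place of 4-methoxyphenyl on an aromatic carbon). For the measured compounds named here, no measured step touches a hydroxyl on that aryl group; the only step available is the one just named, and it is small. Compound 3 is therefore expected to show a 1.1-fold higher number from compound 2 to compound 3 (0.05 log units; within the scatter), nothing beyond the scatter, with an estimated 15000 nM and a range of 5000 nM to 45000 nM.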

Compound 3, half-maximal inhibitory concentration: 63100 nM
Beside the measured number, compound 3's estimate is 4.2-fold (0.62 log units) below it, and the stated range ends below it.
By their numbers in this assay, from the lowest: compounds 2 and 1 (each within the scatter of the next); then compound 3.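

In this assay, this position proves sensitive to the aryl group it carries: 2-hydroxyphenyl gives a clear rise over both earlier groups (a 4.7-fold higher number from compound 2 to compound 3 (0.68 log units; beyond the scatter)) and (a 3.5-fold higher number from compound 1 to compound 3 (0.54 log units; beyond the scatter)), while methoxy and chloro had stayed within the scatter of each other. Compound 3 thus stands apart from that pair, though only by modest steps. Nothing available here bears on why the number rises. The compounds shown leave open whether the hydroxyl itself or its location on the aryl ring carries the step, a question that 4-hydroxyphenyl or 2-methoxyphenyl would separate.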